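Swapping an aryl ring for furan in a cytotoxicity series

The source may report more compounds than this note shows. Statements on the series, on what has been measured and on what is new or still open speak of the compounds shown alone.

Three compounds built on a shared core have all been tested in an ADME assay on HEK293 cells (Homo sapiens) for cytotoxicity, read by CellTiter-Glo and resazurin assay, with a stated time of 72 h; on this read-out lower numbers stand for an effect already at smaller amounts and higher numbers for an effect only at larger amounts of compound. Compound 1, `CC(C)N(Cc1cccc(OCCCCCC(=O)O)c1)C(=O)c1ccc(-c2ccc3cc[nH]c3c2)cc1`, gives > 26000 nM in this assay, a limit of the test rather than a number. Compound 2, `CC(C)N(Cc1cccc(OCCCCCC(=O)O)c1)C(=O)c1ccc(-c2cc3ccccc3n2S(=O)(=O)c2ccccc2)cc1`, likewise reports > 26000 nM, again only a limit. Compound 3, `CCOC(=O)CCCCCOc1cccc(CN(C(=O)c2ccc(-c3cccc(N(C)C)c3)cc2)C(C)C)c1`, also stops at the limit with > 26000 nM. Compound 3 therefore stands exactly where its two companions stand: all three sit at the same ceiling, (the limit of > 26000 nM in this assay, at which 3 of the 3 values shown sit), and none of them can be called more or less toxic than another on these numbers.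

Compound 4, `CCOC(=O)CCCCCOc1cccc(CN(C(=O)c2ccc(-c3ccco3)cc2)C(C)C)c1`, has not been measured. It differs from compound 3 in one place: furan-2-yl in place of 3-(dimethylamino)phenyl on an aromatic carbon. Going by the values given here, no two measured compounds in this set differ by a single change, so there is no measured step to draw on for this swap. With compound 3 reporting only the limit > 26000 nM, the same outcome seems the most likely for the furan-2-yl analogue. The expected step is a step that the limit leaves unreadable from compound 3 to compound 4, that is, none beyond the usual scatter. Compound 4 is estimated at 30000 nM, within a range from 15000 nM to 60000 nM, most probably reported once more as a limit.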

Compound 4, half-maximal effective concentration: > 26000 nM
Compound 4 was reported as a limit; the forecaster's own chance of this, stated with the estimate: 85%; the middle value does not contradict the limit.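

In this assay compound 4 gives > 26000 nM, a limit and not a number. Going by these compounds alone, compound 3 also stands at a limit, so no step between compound 3 and compound 4 can be read. The compounds shown leave open at what amount, if any, each would affect these cells, since all share one ceiling: the limit of > 26000 nM in this assay, at which 4 of the 4 values shown sit.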